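A few compounds are considered here, and "the series" means these few. Any claim that something is new, unique, unknown or untested is made for them only; others in the source may bear on it.

Measured so far:
compound 1, `CC(C)CN(c1ccc(C#N)cc1)S(=O)(=O)c1ccc2c(c1)C(O)CC(C1CCOCC1)O2`, 3.07 in a physicochemical assay for lipophilicity, at pH 7.4; on this read-out lower numbers stand for lower lipophilicity and higher numbers for higher lipophilicity
compound 2, `CCc1ccc(N(CC(C)C)S(=O)(=O)c2ccc3c(c2)C(N)CC(C2CCOCC2)O3)cc1`, 3.08
compound 3, `CCc1ccc(N(CC(C)C)S(=O)(=O)c2ccc3c(c2)C(OC)CC(C2CCOCC2)O3)cc1`, 4.69

Among these three numbers compound 1 stands lowest. Its nearest neighbour is compound 2, which lies within the scatter of it, so no order between compound 1 and compound 2 can be claimed. Compound 3 is the furthest, and the gap from compound 1 to compound 3 is beyond the scatter. Going by the values given here, the one step measured in a single place, a number 1.61 log units higher from compound 2 to compound 3 (beyond the scatter), concerns the saturated ring carbon and not the aryl group on the sulfonamide nitrogen.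

The unmeasured compound 4, `Cc1ccc(N(CC(C)C)S(=O)(=O)c2ccc3c(c2)C(O)CC(C2CCOCC2)O3)c(C)c1`, differs from compound 1 in one place: 2,4-dimethylphenyl in place of 4-cyanophenyl on a sulfonamide nitrogen.

Among the compounds with values here, no measured step bears on this exchange; compound 2 and compound 3 carry a different aryl group, but they also differ from compound 1 at the saturated ring carbon, so their values show nothing about the aryl group alone. The account therefore rests on the structural change itself: a nitrile leaves and two methyl groups enter. Compound 4 is expected to give a value of 4.3 in this assay, with a range from 3.7 to 4.9. This expectation amounts to an estimated step of a number 1.23 log units higher from compound 1 to compound 4 (beyond the scatter), upward and beyond the scatter.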

Compound 4, distribution coefficient: 4.19
Compound 4: middle estimate off by 0.11 log units, on the high side; the measured number falls inside the stated range.
By their numbers in this assay, from the lowest: compounds 1 and 2 (each within the scatter of the next); then compound 4; then compound 3.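

In this assay, the exchange of 4-cyanophenyl for 2,4-dimethylphenyl on the sulfonamide nitrogen now has a measured size of its own (a number 1.12 log units higher from compound 1 to compound 4 (beyond the scatter)), with the rest of the molecule unchanged. Going by these compounds alone, this is the first step measured in one place at this aryl group, and it shows that the exchange alone, with the saturated ring carbon left as in compound 1, gives a large step, as the change at that carbon did (a number 1.61 log units higher from compound 2 to compound 3 (beyond the scatter)). Nothing measured here accounts for the size or direction of the step, so it stands as an observation without a stated cause.

The compounds shown do not separate the departure of the nitrile from the arrival of the two methyl groups, and an unsubstituted phenyl or a pyridine ring on the sulfonamide nitrogen would bear on that question. Also open is whether a step of this size would recur with amino or methoxy on the saturated ring carbon, as no pair among the compounds shown tests the aryl exchange there.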